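Methyl in Place of Chloro at the Cytotoxicity Limit

This account rests on a few compounds, and the source may have more. Where it says the series, first, only, none or still open, it means among the compounds named here.

Three measured compounds share one core and differ only in the aryl group on the ring nitrogen. Compound 1 `COc1ccc(Nc2nc(-c3cccc(F)c3)nc3ccc(F)cc23)cc1` gives 42300 nM in a functional assay on HT29-AK cells (Homo sapiens) for cytotoxicity, read by MTT assay, with a stated time of 48 h; on this read-out higher numbers stand for weaker inhibition and lower numbers for stronger inhibition. Compound 2 `Fc1cccc(-c2nc(Nc3cccc(Cl)c3)c3cc(F)ccc3n2)c1` reaches only a limit of the assay in this assay, at > 50000 nM. Compound 3 `Nc1cccc(Nc2nc(-c3cccc(F)c3)nc3ccc(F)cc23)c1` likewise stops at a limit in this assay, > 50000 nM. The steps of an at least 1.1-fold higher number from compound 1 to compound 2 (0.07 log units; that floor lies within the scatter) and an at least 1.1-fold higher number from compound 1 to compound 3 (0.07 log units; that floor lies within the scatter) sit at their floor, and a step that the two limits leave unreadable from compound 2 to compound 3 because of the limit of > 50000 nM in this assay, at which 2 of the 3 values shown sit. Compound 4 `Cc1cccc(Nc2nc(-c3cccc(F)c3)nc3ccc(F)cc23)c1` carries methyl in place of chloro on an aromatic carbon. Going by the values given here, no measured step swaps chloro for methyl, so direction cannot be read; with compound 2 standing at a limit, the step expected is a number no higher from compound 2 to compound 4 (the limit leaves the size open), none beyond the scatter. Compound 4 is therefore estimated at 50000 nM, between 20000 nM and 120000 nM.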

Compound 4, half-maximal inhibitory concentration: > 50000 nM
Compound 4: no number, only a limit (the forecaster's own chance of this, stated with the estimate: 60%); the middle value lies on the limit itself.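

Methyl on this aromatic carbon gives no number either, so chloro, amino and methyl all end at the same limit in this assay, and the steps among them cannot be read because none has a value to compare: the limit of > 50000 nM in this assay, at which 3 of the 4 values shown sit. The one readable step is an at least 1.1-fold higher number from compound 1 to compound 4 (0.07 log units; that floor lies within the scatter), so 3-methylphenyl is not separated from 4-methoxyphenyl on the nitrogen.

As far as these compounds go, how far methyl, chloro and amino truly differ stays open. So does whether a hydroxyl, a nitrile or a carboxylic acid on this aromatic carbon would give a number under the limit.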